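The source may hold more compounds than are shown below. What is called first, only, known or untested is meant among the compounds shown, and "the series" means these compounds.

Of the compounds shown here, three sharing one core have been measured in an in vitro functional assay on HEK285-7 cells for antagonist activity at prostaglandin D2 receptor 2 (Homo sapiens), read by BRET and beta-arrestin recruitment; on this read-out lower numbers stand for stronger inhibition and higher numbers for weaker inhibition. Compound 1 `Nc1nc(-c2ccc(Cl)cc2)c(CC(=O)O)s1` reaches only the limit of the limit of > 100000 nM in this assay, at which 1 of the 3 values shown sits, so compound 1 gives > 100000 nM and no number. Compound 2 `Cc1nc(-c2ccc(Cl)cc2)c(CC(=O)O)s1` gives 41000 nM, the highest of the two numbers; compound 3 `O=C(O)Cc1sc(NCc2ccccc2)nc1-c1ccc(Cl)cc1` gives 2300 nM. The steps are an at least 2.4-fold lower number from compound 1 to compound 2 (0.38 log units; beyond the scatter), an at least 43-fold lower number from compound 1 to compound 3 (1.63 log units; beyond the scatter) and an 18-fold lower number from compound 2 to compound 3 (1.25 log units; beyond the scatter). Compound 4 `O=C(O)Cc1sc(COc2ccc(Cl)cc2)nc1-c1ccc(Cl)cc1` differs from compound 2 by 4-chlorophenoxy in place of hydrogen on a saturated chain carbon bound to an aromatic carbon. The step from compound 2 to compound 3, where a larger aromatic group also entered, was large, so a large drop is expected here as well, a 14-fold lower number from compound 2 to compound 4 (1.14 log units; beyond the scatter). Compound 4 is therefore estimated at 3000 nM, between 800 nM and 12000 nM.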

Compound 4, half-maximal inhibitory concentration: 370 nM
Beside the measured number, compound 4's estimate is 8.1-fold (0.91 log units) above it; measured number below the stated range.
By their numbers in this assay, from the lowest: compound 4; then compound 3; then compound 2. At a limit, above all of these: compound 1.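

Adding 4-chlorophenoxy to the saturated chain carbon bound to the aromatic carbon gives a 110-fold lower number from compound 2 to compound 4 (2.04 log units; beyond the scatter), so this position accepts a large aromatic group attached through carbon and oxygen. A low number here therefore does not depend on the nitrogen-linked benzyl of compound 3. Within the data shown here, nothing measured so far explains why the number falls. The compounds shown do not separate the contributions of the chlorine, the oxygen and the ring. A plain phenoxy group or a longer chain carrying the same ring would address that question.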